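This account rests on a few compounds, and the source may have more. Where it says the series, first, only, none or still open, it means among the compounds named here.

Of the compounds shown here, two that share one core have been tested so far. Compound 1 `CC[C@H](C)[C@H](NC(=O)CN(c1nc(Cl)nc2[nH]cnc12)C1CC1)C(=O)O` and compound 2 `NCCCC[C@H](NC(=O)CN(c1nc(Cl)nc2[nH]cnc12)C1CC1)C(=O)OCc1ccccc1` were examined in a functional assay on the whole organism (Tail, strain ICR) with Mus musculus as the target, in the tail flick test, with a stated time of 150 min, at a dose of 25 umol/kg by the oral route (a higher number here means a stronger effect of the compound at the dose given, a lower number a weaker effect), where compound 1 gives 6.71% and compound 2 gives 9.88%. Compound 2 is the higher of the two numbers, but its nearest neighbour, compound 1, lies only a few points below it, a gap that sits within the usual scatter of this kind of measurement, so the two cannot be told apart on these numbers.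

The step now considered leads from compound 2 to compound 3 `NCCCC[C@H](NC(=O)CN(c1nc(Cl)nc2[nH]cnc12)C1CC1)C(=O)O`. The change is a single one: hydrogen in place of benzyl on an oxygen next to a carbonyl group. Put another way, benzyloxycarbonyl becomes carboxy, so compound 3 carries the same carboxy end that compound 1 already has.

Among the compounds with values here, no measured pair differing in only one place is available to gauge such a change, so the expectation rests on the two values alone. Because compound 1, which also ends in carboxy, gives 6.71%, an expected step of a number 2.9 percentage points lower from compound 2 to compound 3 (within the scatter) is estimated, none beyond the scatter. Compound 3 is therefore expected to give about 7% in this assay, estimated within a range from 0% to 20%.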

Compound 3, a percentage reported as activity, at one dose (the size of the read-out at that dose, not a potency): 11.6%
The estimate for compound 3 lay 4.6 percentage points below the measured number; the range from low to high includes it.
By their numbers in this assay, from the lowest: compounds 1, 2 and 3 (each within the scatter of the next).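

In this assay, hydrogen in place of benzyl on an oxygen next to a carbonyl group gives a number 1.7 percentage points higher from compound 2 to compound 3 (within the scatter), so at this dose the benzyloxycarbonyl end and the carboxy end cannot be told apart, even though a whole six-membered aromatic ring leaves with the benzyl. Within the data shown here, the new compound also allows a first look at a second place, the side chain on the saturated chain carbon: 4-aminobutyl in place of sec-butyl gives a number 4.9 percentage points higher from compound 1 to compound 3 (within the scatter), so these two chains cannot be told apart here either, and neither change moves the read-out by more than repeated measurements of this kind would. Nothing available here explains these numbers or shows what happens to the compounds in the animal.

Going by these compounds, whether a much smaller group on that oxygen, such as methyl, or a different side chain, such as a 3-guanidinopropyl chain or a short hydroxymethyl group, would give a step beyond the scatter remains open. On these data alone, all three numbers also come from a single dose and a single time, so how these compounds compare at other doses or times is unknown.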